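Tetrazole in Place of Cyanocarbamoyl on a Weak Binder

This account rests on a few compounds, and the source may have more. Where it says the series, first, only, none or still open, it means among the compounds named here.

Compound 1 `CC[C@H](C)[C@H](NC(=O)c1cccc(Cn2ccnc2)c1)C(N)=O` and compound 2 `CC[C@H](C)[C@H](NC(=O)c1cccc(Cn2ccnc2)c1)C(=O)NC#N` share one core and differ in a single group. In an assay on HEK293 cells for displacement of a labelled ligand from Type-2 angiotensin II receptor (Homo sapiens), tested at 1 uM (a lower number here means a weaker effect, a higher number a stronger effect of the compound at the concentration tested), compound 1 is recorded as "not active" (no number reported), while compound 2 gives 6%. Going by the values given here, compound 2 therefore holds the only number reported, with compound 1 beside it without one. Compound 3 `CC[C@H](C)[C@H](NC(=O)c1cccc(Cn2ccnc2)c1)c1nn[nH]n1` carries the change (2H-tetrazol-5-yl in place of cyanocarbamoyl on a saturated chain carbon bound to an amide-type nitrogen and a saturated chain carbon). Among the compounds with values here, no step between measured compounds is available, so the expectation rests on compound 2 alone. Compound 3 is expected to give 10% in this assay, within 0% to 30%. The step of a number 4 percentage points higher from compound 2 to compound 3 (within the scatter) is expected to stay within the usual scatter.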

Compound 3, a percentage reported as inhibition, at one concentration (the size of the read-out at that concentration, not a potency): "not active" (no number reported)
The entry for compound 3 holds no number, so the estimate cannot be set against anything.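

Going by these compounds alone, compound 3 has no number, so no step from compound 2 can be read in this assay. Nothing shown bears on this result. The compounds shown leave open how swapping cyanocarbamoyl for 2H-tetrazol-5-yl affects the read-out.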